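Adding a Chloro Group to a Cathepsin S Inhibitor

The compounds below may be only part of what the source reports. "The series", "measured", "known", "first", "only" and "open" are said of these compounds alone.

Of the compounds shown here, three have been tested so far in an assay on isolated protein for inhibition of cathepsin S (Homo sapiens), read by fluorescence, with a stated time of 20 min; on this read-out lower numbers stand for stronger inhibition and higher numbers for weaker inhibition. Compound 1 `N#CCNC(=O)[C@@H]1C[C@@H](S(=O)(=O)c2ccccc2C(F)(F)F)C[C@H]1C(=O)N1CCOCC1` gives 0.9 nM, and compound 2 `CN(C)C(=O)[C@@H]1C[C@H](S(=O)(=O)c2ccccc2)C[C@H]1C(=O)NC1(C#N)CC1` gives 6 nM. Compound 3 `N#CCNC(=O)[C@@H]1CN(S(=O)(=O)c2ccccc2)C[C@H]1C(=O)N1CCOCC1` gives 271 nM, which is the highest of the three numbers and therefore marks it as the weakest inhibitor of the set, since its gaps to compound 2 and to compound 1 both lie beyond the usual scatter.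

The next compound keeps the core of compound 3 and changes one thing: compound 4 `N#CCNC(=O)[C@@H]1CN(S(=O)(=O)c2ccccc2Cl)C[C@H]1C(=O)N1CCOCC1` carries chloro in place of hydrogen on an aromatic carbon. Among the measured compounds shown here, no measured pair in this set differs by exactly this change, so the size of the step can only be guessed. Compound 1, which also bears a group on that same ring position, differs from compound 3 in more than one place, so the value of compound 1, 0.9 nM, can serve only as a loose hint that a group there is compatible with strong inhibition.

On this basis a modest gain in potency is expected, written as a 3.9-fold lower number from compound 3 to compound 4 (0.59 log units; beyond the scatter). Compound 4 is therefore estimated at 70 nM, with a plausible range from 20 nM to 250 nM.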

Compound 4, half-maximal inhibitory concentration: 12 nM
Estimate against measurement, compound 4: 5.8-fold (0.77 log units) above, outside the stated range (below it).
By their numbers in this assay, from the lowest: compound 1; then compounds 2 and 4 (each within the scatter of the next); then compound 3.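

Replacing one hydrogen with chloro on the aromatic ring, ortho to a large group, gives a 23-fold lower number from compound 3 to compound 4 (1.35 log units; beyond the scatter) in this assay, a large change for the addition of a single heavy atom. Among the compounds shown here, this is the first step in the set that can be read cleanly, since the two compounds differ in one place only, so the ring position of compound 1 no longer rests on a loose hint: on the core of compound 3, this position responds strongly to substitution. Nothing measured here accounts for the size of the step.

The compounds shown leave open whether the gain belongs to chloro itself or would also come with another small group at this position, such as fluoro, methyl or methoxy, and whether chloro would have a similar effect elsewhere on the ring. Going by these compounds, it also remains open whether the same change would bring a step of similar size on another core, such as the one carrying the unsubstituted phenyl sulfone in compound 2.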